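This account rests on a few compounds, and the source may have more. Where it says the series, first, only, none or still open, it means among the compounds named here.

Measured in an ADME assay on microsomes from liver (Mus musculus) for metabolic stability; on this read-out higher numbers stand for a longer-lived compound and lower numbers for a shorter-lived compound:
Compound 1 `CC(C)C(c1ncc[nH]1)c1ccc(-c2ccc3cccc(F)c3c2)[nH]c1=O`: < 0.0667 h, a limit of the assay
Compound 2 `CC(C)C(Cc1nnn[nH]1)c1ccc(-c2ccc3cccc(F)c3c2)[nH]c1=O`: 0.853 h

Going by the values given here, compound 2 holds the only actual number in this assay. Compound 3 `CC(C)C(c1ccc(-c2ccc3cccc(F)c3c2)[nH]c1=O)N1CCNC1=O` differs from it at one place: 2-oxoimidazolidin-1-yl in place of (1H-tetrazol-5-yl)methyl on a saturated chain carbon bound to an aromatic carbon and a saturated chain carbon. Among the compounds with values here, the one measured step at that place, an at least 12-fold higher number from compound 1 to compound 2 (1.10 log units; beyond the scatter), is large, so a step beyond the scatter is expected here too. The expected direction is downward, since compound 3, like compound 1, carries its ring on that saturated chain carbon without the methyl link of compound 2. In this assay the expected step is a 2.8-fold lower number from compound 2 to compound 3 (0.45 log units; beyond the scatter), toward a shorter-lived compound. For compound 3 the estimated half-life is 0.3 h, with an expected range of 0.08 h to 1 h.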

Compound 3, half-life: 0.682 h
Estimate against measurement, compound 3: 2.3-fold (0.36 log units) below, and the stated range covers the measured number.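

In this assay, a ring set on the saturated chain carbon without a methyl link can match the tetrazole side chain: 2-oxoimidazolidin-1-yl in place of (1H-tetrazol-5-yl)methyl gives a 1.3-fold lower number from compound 2 to compound 3 (0.10 log units; within the scatter). The short half-life of compound 1 therefore does not follow from the missing link alone, as the change of ring gives an at least 10-fold higher number from compound 1 to compound 3 (1.00 log units; beyond the scatter). Compound 1 stands at a limit, so this step gives only a minimum size: the limit of < 0.0667 h in this assay, at which 1 of the 3 values shown sits.

The compounds shown leave open which feature of 2-oxoimidazolidin-1-yl matters. They also leave open how an open-chain urea or a carboxylic acid would fare at this place.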